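The source may hold more compounds than are shown below. What is called first, only, known or untested is meant among the compounds shown, and "the series" means these compounds.

Measured compounds:
Compound 1 `Nc1cc(-c2ccc(Cl)cc2)nn1-c1cccc(Cl)c1`: in a functional assay on Jurkat cells (Homo sapiens) for inhibition, read by MTT assay, with a stated time of 72 h (on this read-out higher numbers stand for weaker inhibition of growth and lower numbers for stronger inhibition of growth), compound 1 reaches only > 100000 nM, which is a limit of the assay and not a number.
Compound 2 `CN(C)/C=N/c1c(C=O)c(-c2ccccc2)nn1-c1ccccc1`: in this assay compound 2 gives 23500 nM.
Compound 3 `Cc1ccc(-c2nn(-c3ccc(Br)cc3)c(/N=C/N(C)C)c2C=O)cc1`: in this assay compound 3 gives 6700 nM.

Of the two numbers that were obtained, compound 2 holds the higher one; compound 3 sits lower, by a gap beyond the usual scatter. The third value is a limit, as stated by the limit of > 100000 nM in this assay, at which 1 of the 3 values shown sits. Going by the values given here, no pair of measured compounds differs in one place only, so no step between them can be read off.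

The compound not yet measured is compound 4 `CN(C)/C=N/c1cc(-c2ccccc2)nn1-c1ccccc1`. It differs from compound 2 by hydrogen in place of formyl on an aromatic carbon. Compound 1 also carries no formyl on its core, and in this assay compound 1 reaches only its limit > 100000 nM. Among the compounds with values here, on that ground, and with no measured step of this kind available, compound 4 is expected to show a weakening of growth inhibition beyond the scatter, a step of a 2.6-fold higher number from compound 2 to compound 4 (0.41 log units; beyond the scatter), and an estimated value of 60000 nM, within a range from 15000 nM to 200000 nM.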

Compound 4, concentration for 50% growth inhibition: > 100000 nM
Compound 4 was reported as a limit; the forecaster's own chance of this, stated with the estimate: 40%; at least 1.6-fold (0.22 log units) between middle value and limit.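

Hydrogen in place of formyl on an aromatic carbon gives an at least 4.2-fold higher number from compound 2 to compound 4 (0.62 log units; beyond the scatter) in this assay, the first step in this set that can be read between two compounds differing in one place only, and it lies beyond the scatter. From the compounds shown here alone, compound 4 stands at > 100000 nM, which is a limit of the assay and not a number, so the step sets only a lower bound on the size of this change and its full size stays unknown. For this pair, then, a numerical value is obtained only with the formyl group on this carbon of the five-membered aromatic ring, and compound 4 joins compound 1 at the limit: the limit of > 100000 nM in this assay, at which 2 of the 4 values shown sit.

The compounds shown leave open whether another group on this aromatic carbon, such as a carboxylic acid, a nitrile or a hydroxymethyl group, would keep a numerical value in this assay or would also end at the limit. They also leave open whether the loss of formyl would have a similar effect on the core of compound 3, which carries a methyl group and a bromine atom on its two outer benzene rings, and the data give no cause for the step itself.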